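Amide nitrogen substituent change, compound 1 to compound 3

A few compounds are considered here, and "the series" means these few. Any claim that something is new, unique, unknown or untested is made for them only; others in the source may bear on it.

Among the compounds with values here, in a functional assay on MCF7 cells (Homo sapiens) for inhibition, read by MTT assay, with a stated time of 24 h (on this read-out lower numbers stand for stronger inhibition and higher numbers for weaker inhibition), compound 1 (`O=C(Cn1c(=O)c(/C=C\c2ccncc2)nc2ccccc21)Nc1ccc(F)cc1`) gives 49000 nM, the only true number so far. Compound 2 (`Cc1ccccc1NC(=O)Cn1c(=O)c(/C=C\c2ccncc2)nc2ccccc21`) gives > 100000 nM, which is a limit of this assay. Within the data shown here, the single measured step at this site is an at least 2.0-fold higher number from compound 1 to compound 2 (0.30 log units; that floor lies within the scatter), and it replaces 4-fluorophenyl with 2-methylphenyl on the amide-type nitrogen. Compound 3 (`COc1ccc(NC(=O)Cn2c(=O)c(/C=C\c3ccncc3)nc3ccccc32)cc1OC`) has 3,4-dimethoxyphenyl in place of 4-fluorophenyl at that nitrogen: 3,4-dimethoxyphenyl in place of 4-fluorophenyl on an amide-type nitrogen. With only an at least 2.0-fold higher number from compound 1 to compound 2 (0.30 log units; that floor lies within the scatter) as a guide, the expected step in this assay is a 1.2-fold higher number from compound 1 to compound 3 (0.09 log units; within the scatter), none beyond the scatter. Compound 3 is estimated at 60000 nM, with an expected range of 20000 nM to 150000 nM.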

Compound 3, half-maximal inhibitory concentration: > 100000 nM
Compound 3 gave a limit, no number; the forecaster's own chance of this, stated with the estimate: 30%; middle value at least 1.6-fold (0.22 log units) from the limit.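

Replacing 4-fluorophenyl on the amide-type nitrogen with 3,4-dimethoxyphenyl gives an at least 2.0-fold higher number from compound 1 to compound 3 (0.30 log units; that floor lies within the scatter), so a second replacement at this position also ends at a limit in this assay, and the printed floor stays within the scatter. The step between compound 2 and compound 3 cannot be read. The position now has only one true number, and the rest of the series sits at one ceiling: the limit of > 100000 nM in this assay, at which 2 of the 3 values shown sit.

From the compounds shown here alone, how far compound 3 really lies from compound 1 remains open. Also open, going by these compounds, is what an unsubstituted phenyl, or a phenyl carrying an amine or a carboxylic acid, would give on this nitrogen.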